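Series notes: pyrrolidine nitrogen substituent, compound 3 to 4

A few compounds are considered here, and "the series" means these few. Any claim that something is new, unique, unknown or untested is made for them only; others in the source may bear on it.

Measured so far in a functional assay on U2OS cells for antagonist activity at proto-oncogene Wnt-3 (Homo sapiens), read by a luciferase reporter, with a stated time of 18 h; on this read-out higher numbers stand for an effect only at larger amounts of compound and lower numbers for an effect already at smaller amounts:
compound 1 `CN(C)CC(=O)N1CCC(NS(=O)(=O)c2cc(S(=O)(=O)c3ccccc3)ccc2C(F)(F)F)CC1` gives 280 nM
compound 2 `CC(C)(C)OC(=O)N1CCC[C@@H]1C(=O)N1CCC(NS(=O)(=O)c2cc(S(=O)(=O)c3ccccc3)ccc2C(F)(F)F)CC1` gives 210 nM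
compound 3 `CCNC(=O)N1CCC[C@H]1C(=O)N1CCC(NS(=O)(=O)c2cc(S(=O)(=O)c3ccccc3)ccc2C(F)(F)F)CC1` gives 90 nM

Compound 3 has the lowest number of the three in this assay; the step of a 2.3-fold lower number from compound 2 to compound 3 (0.37 log units; beyond the scatter) and the step of a 3.1-fold lower number from compound 1 to compound 3 (0.49 log units; beyond the scatter) are both beyond the scatter, so compound 3 stands apart from the other two. The step of a 1.3-fold lower number from compound 1 to compound 2 (0.12 log units; within the scatter) is within the scatter.

Compound 4 `CN1CCC[C@H]1C(=O)N1CCC(NS(=O)(=O)c2cc(S(=O)(=O)c3ccccc3)ccc2C(F)(F)F)CC1` is not yet measured. The change is methyl in place of ethylcarbamoyl on an amine nitrogen in a ring. Within the data shown here, no measured step changes this nitrogen substituent to a group as small as methyl. Among the measured compounds shown here, the steps that bear on it are those into compound 3, where the ethylcarbamoyl on the ring nitrogen gave the lower number relative to either the tert-butoxycarbonyl of compound 2 or the (dimethylamino)methyl of compound 1. Taking the ethylcarbamoyl away is therefore expected to move the number back toward those of compound 1 and compound 2, a modest step in the direction of higher numbers, with the direction more certain than the size.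

Compound 4 is expected to give 200 nM in this assay, estimated between 80 nM and 600 nM, a step of a 2.2-fold higher number from compound 3 to compound 4 (0.35 log units; beyond the scatter).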

Compound 4, half-maximal effective concentration: 230 nM
For compound 4 the middle estimate is 1.2-fold (0.06 log units) below the measured one, and the stated range covers the measured number.
By their numbers in this assay, from the lowest: compound 3; then compounds 2, 4 and 1 (each within the scatter of the next).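

Among these compounds, putting methyl in place of ethylcarbamoyl on the amine nitrogen in the ring, with the rest of compound 3 unchanged, gives the first measured step at this nitrogen in this assay (a 2.6-fold higher number from compound 3 to compound 4 (0.41 log units; beyond the scatter)), so the low number of compound 3 goes with the ethylcarbamoyl and not with the 1-substituted pyrrolidin-2-yl carbonyl alone. Compound 4 does not stand apart from the two earlier compounds (a 1.1-fold higher number from compound 2 to compound 4 (0.04 log units; within the scatter); a 1.2-fold lower number from compound 1 to compound 4 (0.09 log units; within the scatter)), so among these four only compound 3 separates. Nothing measured here explains the step.

The compounds shown leave open which part of the ethylcarbamoyl matters, as they include no acetyl group, unsubstituted carbamoyl or longer chain on the carbamoyl nitrogen. As far as these compounds go, the unsubstituted ring amine also remains open as a reference point for this position.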